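The compounds below may be only part of what the source reports. "The series", "measured", "known", "first", "only" and "open" are said of these compounds alone.

Compound 1 (`COc1cccc(N(C)S(=O)(=O)C2CC3OC2C(c2ccc(NC(=O)CCCCCCC(=O)O)cc2)=C3c2ccc(O)cc2)c1`), compound 2 (`CN(c1ccc(Cl)cc1)S(=O)(=O)C1CC2OC1C(c1ccc(NC(=O)CCCCCCC(=O)O)cc1)=C2c1ccc(O)cc1`) and compound 3 (`CCN(c1ccc(OC)cc1)S(=O)(=O)C1CC2OC1C(c1ccc(NC(=O)CCCCCCC(=O)O)cc1)=C2c1ccc(O)cc1`) share one core and differ only in the groups on the sulfonamide nitrogen. In a functional assay on MCF7 cells (Homo sapiens) for antiproliferative activity, read by MTT assay, with a stated time of 72 h (on this read-out higher numbers stand for weaker inhibition and lower numbers for stronger inhibition), compound 1 gives 39400 nM, compound 2 gives 13700 nM and compound 3 gives 20300 nM. The number for compound 3 thus falls between the other two and within the scatter of each, as shown by a 1.9-fold lower number from compound 1 to compound 3 (0.29 log units; within the scatter) and a 1.5-fold higher number from compound 2 to compound 3 (0.17 log units; within the scatter). Only a 2.9-fold lower number from compound 1 to compound 2 (0.46 log units; beyond the scatter) lies beyond the scatter, and that step is modest.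

Compound 4 (`CCN(c1cccc(OC)c1)S(=O)(=O)C1CC2OC1C(c1ccc(NC(=O)CCCCCCC(=O)O)cc1)=C2c1ccc(O)cc1`) is related to compound 3 by a single change, (3-methoxyphenyl in place of 4-methoxyphenyl on a sulfonamide nitrogen), which puts 3-methoxyphenyl in place of 4-methoxyphenyl on a sulfonamide nitrogen. Among the measured compounds shown here, no measured step isolates this change. The closest evidence is compound 1, which carries the same 3-methoxyphenyl group but also a methyl group where compound 3 has ethyl. Its a 1.9-fold lower number from compound 1 to compound 3 (0.29 log units; within the scatter) therefore mixes two changes and offers only a weak hint of direction. On the strength of 39400 nM for compound 1, a slightly higher number is expected in this assay, but nothing beyond the scatter. The expected change is a 1.3-fold higher number from compound 3 to compound 4 (0.11 log units; within the scatter). For compound 4 the estimated value is 26000 nM, with an expected range of 14000 nM to 46000 nM.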

Compound 4, half-maximal inhibitory concentration: 37400 nM
Estimate against measurement, compound 4: 1.4-fold (0.16 log units) below; low and high end bracket the measured number.
By their numbers in this assay, from the lowest: compounds 2, 3, 4 and 1 (each within the scatter of the next, the first and the last beyond it).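

Among the compounds shown here, with ethyl held on the sulfonamide nitrogen, compound 3 and compound 4 isolate the exchange of 4-methoxyphenyl for 3-methoxyphenyl for the first time, and in this assay this exchange stays within the scatter (a 1.8-fold higher number from compound 3 to compound 4 (0.27 log units; within the scatter)). For the compounds shown here, with 3-methoxyphenyl held, the exchange of methyl for ethyl on the same nitrogen also stays within the scatter (a 1.1-fold lower number from compound 1 to compound 4 (0.02 log units; within the scatter)), so neither single change can be told apart from repeat measurement here, while the only new step beyond the scatter is modest and alters the aryl and alkyl groups together (a 2.7-fold higher number from compound 2 to compound 4 (0.44 log units; beyond the scatter)). No measured property or other supporting data accompany these compounds to explain the numbers.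

The compounds shown leave open how much of that last step belongs to the 4-chlorophenyl group alone, since that group appears only with methyl on the nitrogen and never with ethyl. They also leave open whether a propyl group or a hydrogen on the sulfonamide nitrogen, or a hydroxyl or fluorine on its phenyl ring, would move the number beyond the scatter.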